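The source may hold more compounds than are shown below. What is called first, only, known or untested is meant among the compounds shown, and "the series" means these compounds.

Measured in an ADME assay on MT4 cells (Homo sapiens) for cytotoxicity, read by MTT assay, with a stated time of 4 days; on this read-out lower numbers stand for higher toxicity in this test and higher numbers for lower toxicity in this test:
compound 1 `Cc1cc(-c2ccccc2F)cc(C)c1Nc1ccnc(Nc2ccc(C#N)cc2)n1` gives 2120 nM;
compound 2 `COc1ccccc1-c1cc(C)c(Nc2ccnc(Nc3ccc(C#N)cc3)n2)c(C)c1` gives 940 nM;
compound 3 `Cc1cc(-c2cccc(Cl)c2)cc(C)c1Nc1ccnc(Nc2ccc(C#N)cc2)n1` gives 2160 nM.

Compound 1 stands second highest of the three numbers. Its nearest neighbour is compound 3, the step being a 1.0-fold higher number from compound 1 to compound 3 (0.01 log units; within the scatter); the furthest is compound 2, the step being a 2.3-fold lower number from compound 1 to compound 2 (0.35 log units; beyond the scatter). Compound 4 `Cc1cc(-c2cc(F)cc(F)c2)cc(C)c1Nc1ccnc(Nc2ccc(C#N)cc2)n1` differs from compound 1 in one place: 3,5-difluorophenyl in place of 2-fluorophenyl on an aromatic carbon. Of the measured steps, the one most like it is the exchange of one substituted phenyl for another in a 1.0-fold higher number from compound 1 to compound 3 (0.01 log units; within the scatter), which stayed within the scatter, whereas only the methoxy of compound 2 gave a modest lowering. No step beyond the scatter is therefore expected in this assay for compound 4: a 1.1-fold higher number from compound 1 to compound 4 (0.04 log units; within the scatter). Compound 4 is estimated at 2300 nM, within 1100 nM to 4800 nM.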

Compound 4, half-maximal cytotoxic concentration: 3910 nM
Compound 4: middle estimate off by 1.7-fold (0.23 log units), on the low side, within the range that was stated.
By their numbers in this assay, from the lowest: compound 2; then compounds 1, 3 and 4 (each within the scatter of the next).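

In this assay, the 3,5-difluorophenyl group stays within the scatter of both the 2-fluorophenyl group (a 1.8-fold higher number from compound 1 to compound 4 (0.27 log units; within the scatter)) and the 3-chlorophenyl group (a 1.8-fold higher number from compound 3 to compound 4 (0.26 log units; within the scatter)), so all three halogen-bearing phenyl groups read alike at this position. The 2-methoxyphenyl group remains the one exception, and the gap to the new group is wider (a 4.2-fold higher number from compound 2 to compound 4 (0.62 log units; beyond the scatter)). Nothing at hand explains this gap. Open, on these data alone, is whether a phenyl group carrying an amine or a carboxylic acid would read like the halogen-bearing groups or like the 2-methoxyphenyl group.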